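Ethyl-to-methyl trim on the enone of compound 1

The source may report more compounds than this note shows. Statements on the series, on what has been measured and on what is new or still open speak of the compounds shown alone.

Measured so far:
compound 1, `C=C(CC)C(=O)c1ccc(OC(C)C(=O)OC)c(C)c1C`: 4600 nM
compound 2, `C=C(CC)C(=O)c1ccc(OCC(=O)O)cc1Br`: > 60000 nM

Compound 1 carries the only number shown in a functional assay on HL-60 cells (Homo sapiens) for antiproliferative activity, with a stated time of 72 h; a higher number here means a weaker inhibitor of growth, a lower number a stronger inhibitor of growth; the other entry is a limit. For compound 2 that entry is the limit of > 60000 nM in this assay, at which 1 of the 2 values shown sits, a limit of the assay and not a number. For the measured compounds named here, no two measured compounds differ in a single place, so no measured step is available; the series rests on compound 1 alone.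

Compound 3, `C=C(C)C(=O)c1ccc(OC(C)C(=O)OC)c(C)c1C`, has not yet been measured. It differs from compound 1 by hydrogen in place of methyl on a saturated chain carbon bound to a double-bonded chain carbon. Going by the values given here, the step is one carbon at the end of a short chain, and no measured step informs its size, so the expectation is a change of no more than the usual scatter, with no clear direction. The expected step of a 1.3-fold higher number from compound 1 to compound 3 (0.12 log units; within the scatter) is therefore put near zero. Compound 3 is expected at 6000 nM, within a range of 2500 nM to 15000 nM.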

Compound 3, concentration for 50% growth inhibition: 6000 nM
The estimate for compound 3 equals the measured number at the digits printed; low and high end bracket the measured number.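

For the compounds shown here, the series now holds a 1.3-fold higher number from compound 1 to compound 3 (0.12 log units; within the scatter) as its first step in a single place in this assay and it gives a direct reading that the earlier compounds could not give. On this saturated chain carbon bound to a double-bonded chain carbon, hydrogen in place of methyl leaves compound 3 and compound 1 indistinguishable in this read-out, so the terminal methyl of the ethyl group is not required for the growth inhibition measured with compound 1. No measured value bears on the cause of this step.

A longer chain such as propyl, or an amine or a hydroxyl group on this carbon, remains an open test of how much this position tolerates. Also open, going by these compounds, is whether the same trim gives a similar result with an amide in place of the methyl ester.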